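The source may report more compounds than this note shows. Statements on the series, on what has been measured and on what is new or still open speak of the compounds shown alone.

Of the compounds shown here, three have been tested so far in a functional assay on the whole organism (strain Kunming) with Mus musculus as the target, with a stated time of 0.5 h (on this read-out lower numbers stand for an effect already at smaller amounts and higher numbers for an effect only at larger amounts of compound), and none has yet given an exact number. Compound 1 (`COc1cc(OC)c(OC)cc1/C=C/COC(=O)/C=C/c1c(OC)ccc(OC)c1OC`) gives > 300 mg/kg as a limit of the assay, not a number. Compound 2 (`COc1cc(OC)c(OC)cc1/C=C/COC(=O)/C=C/c1ccccc1C(F)(F)F`) gives > 300 mg/kg as a limit too, so it has no exact place on the scale. Compound 3 (`COc1cc(OC)c(OC)cc1/C=C/COC(=O)/C=C/c1ccc(OC)c(OC)c1OC`) gives > 300 mg/kg as a limit as well. Compound 4 (`COc1cc(OC)c(OC)cc1/C=C/COC(=O)/C=C/c1ccc(F)cc1`) carries 4-fluorophenyl in place of 2-(trifluoromethyl)phenyl on a double-bonded chain carbon bound to a double-bonded chain carbon. For the measured compounds named here, no measured step shows how much such a change can do. Going by the values given here, compound 2 shares the limit of > 300 mg/kg in this assay, at which 3 of the 3 values shown sit, and that is the only guide, so no step beyond the usual scatter is expected in this assay here. The expected change is a number no higher from compound 2 to compound 4 (the limit leaves the size open) as an estimate only. For compound 4 the estimated value is 300 mg/kg (150 mg/kg to 600 mg/kg).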

Compound 4, dose for half-maximal effect: > 300 mg/kg
Compound 4: a limit, no number; the forecaster's own chance of this, stated with the estimate: 80%; the middle value lies on the limit itself.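

For the compounds shown here, compound 2 and compound 4 each give only a limit of the assay, not a number, and no step between them can be read. The dose at which any compound shown acts in this assay stays open.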